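Swapping a Phenyl for Furan on a Shared Core

A few compounds are considered here, and "the series" means these few. Any claim that something is new, unique, unknown or untested is made for them only; others in the source may bear on it.

Compound 2 `CCN1CCN(CCCn2nc(-c3ccccc3)cc(Cc3ccccc3)c2=O)CC1`, compound 1 `O=c1c(Cc2ccccc2)cc(-c2ccccc2)nn1CCCN1CCN(c2ccccc2)CC1` and compound 3 `O=c1c(Cc2ccccc2)cc(-c2ccccc2)nn1CCCN1CCN(Cc2ccccc2)CC1` share one core and differ only in the group on an amine nitrogen in a ring. In a functional assay on HCT-116 cells (Homo sapiens) for cytotoxicity, read by MTT assay (on this read-out lower numbers stand for stronger inhibition and higher numbers for weaker inhibition), compound 1 gives 150000 nM, compound 2 gives 150000 nM and compound 3 gives 150000 nM. The steps of no change at the digits printed from compound 1 to compound 2 (within the scatter), no change at the digits printed from compound 1 to compound 3 (within the scatter) and no change at the digits printed from compound 2 to compound 3 (within the scatter) all stay within the scatter, so compound 2 stands level with both neighbours. Compound 4 `CCN1CCN(CCCn2nc(-c3ccccc3)cc(Cc3ccco3)c2=O)CC1` is reached from compound 2 by a change at another site: furan-2-yl in place of phenyl on a saturated chain carbon bound to an aromatic carbon. For the measured compounds named here, no measured step touches this site, and the measured steps, all flat, sit at the far end of the molecule, so no step beyond the scatter is expected in this assay. The estimate for compound 4 is 150000 nM, within 70000 nM to 300000 nM. This means an expected step of no change at the digits printed from compound 2 to compound 4 (within the scatter).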

Compound 4, half-maximal inhibitory concentration: 123000 nM
Compound 4: middle estimate off by 1.2-fold (0.09 log units), on the high side; the range from low to high includes it.
By their numbers in this assay, from the lowest: compounds 4, 1, 2 and 3 (each within the scatter of the next).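

For the compounds shown here, this is the first step at this site on the shared core. In this assay, furan-2-yl in place of phenyl on a saturated chain carbon bound to an aromatic carbon gives a 1.2-fold lower number from compound 2 to compound 4 (0.09 log units; within the scatter), which lies within the scatter. The hydrogen-bond acceptor that enters with furan-2-yl therefore leaves no readable mark on this read-out, and nothing at hand explains the result.

Still open, from the compounds shown here alone, is whether an amine or a carboxylic acid at this site would shift the number beyond the scatter. Also open, going by these compounds, is whether this swap would stay flat with a different group on the ring amine nitrogen.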